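The source may report more compounds than this note shows. Statements on the series, on what has been measured and on what is new or still open speak of the compounds shown alone.

Measured compounds, all in a functional assay on HeLa cells (Homo sapiens) for antiproliferative activity, read by MTT assay, with a stated time of 48 h; on this read-out lower numbers stand for stronger inhibition and higher numbers for weaker inhibition:

compound 1 `C#Cc1cccc(Nc2ncnc3cc(NC(=O)/C=C/c4ccccc4)sc23)c1`; compound 1 gives 20500 nM
compound 2 `O=C(/C=C/c1ccccc1)Nc1cc2ncnc(Nc3cc(Cl)cc(Cl)c3)c2s1`; compound 2 gives 3210 nM
compound 3 `C#Cc1cccc(Nc2ncnc3sc(NC(=O)/C=C/c4ccccc4)cc23)c1`; compound 3 gives 4640 nM

Compound 1 and compound 2 share a core and differ in one place, (3,5-dichlorophenyl in place of 3-ethynylphenyl on a nitrogen on an aromatic ring). That change produces a 6.4-fold lower number from compound 1 to compound 2 (0.81 log units; beyond the scatter), a step beyond the scatter. Compound 3 has the same atoms as compound 1 joined differently; the difference between the two cores is not broken down here. The values of compound 3 and compound 2 lie within the scatter of each other, so no order between them is claimed, while compound 3 stands beyond the scatter from compound 1.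

Compound 4 `O=C(/C=C/c1ccccc1)Nc1cc2c(Nc3cc(Cl)cc(Cl)c3)ncnc2s1` is not yet measured. It stands to compound 3 as compound 2 stands to compound 1: 3,5-dichlorophenyl in place of 3-ethynylphenyl on a nitrogen on an aromatic ring. The place lines of the two changes read the same word for word, so this is the same change, occurring twice among the compounds shown, once measured and once not.

Among the measured compounds shown here, the expectation for compound 4 in this assay rests on the measured pair alone: because a 6.4-fold lower number from compound 1 to compound 2 (0.81 log units; beyond the scatter) was seen on the core of compound 1, a step of similar direction is expected on the core of compound 3, namely a 4.6-fold lower number from compound 3 to compound 4 (0.67 log units; beyond the scatter), with wider bounds since the change has been seen on only one core. Compound 4 is therefore estimated at 1000 nM, between 350 nM and 3000 nM.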

Compound 4, half-maximal inhibitory concentration: 4 nM
Estimate against measurement, compound 4: 250-fold (2.40 log units) above; measured number below the stated range.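

In this assay, 3,5-dichlorophenyl in place of 3-ethynylphenyl on a nitrogen on an aromatic ring gives a 1200-fold lower number from compound 3 to compound 4 (3.06 log units; beyond the scatter), so the number falls on both cores shown and the direction of the change carries over. The size does not carry over, and the step measured on one core is a poor guide to the step on the other: the same change on two cores in this assay, a 6.4-fold lower number (0.81 log units; beyond the scatter) from compound 1 to compound 2 and a 1200-fold lower number (3.06 log units; beyond the scatter) from compound 3 to compound 4, 180-fold (2.26 log units) apart, beyond the scatter of two such steps

These two pairs show that the outcome of this change depends on the core it sits on, but they do not show which feature of the cores sets the gap, and two cores are too few to give a rule for any further core in the series.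

The compounds shown leave open whether the large step on the core of compound 3 comes from gaining the two chlorines or from losing the ethynyl group, a question that 3-chlorophenyl or unsubstituted phenyl on the same nitrogen on the core of compound 3 would address. Also open, as far as these compounds go, is how far the result depends on the unsubstituted phenyl of the amide side chain, for instance with a methoxy group or an amine on that ring.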